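The compounds below may be only part of what the source reports. "The series", "measured", "known", "first", "only" and "open" are said of these compounds alone.

In a functional assay on the whole organism for inhibition, with Rattus norvegicus as the target, read by cytopathic effect and paw edema, at a dose of 100 mg/kg by the oral route (on this read-out higher numbers stand for more inhibition at the one dose given (going by the name of the read-out) and lower numbers for less inhibition), compound 1 `CN(C)CCNC(=O)c1c(O)c2cccnc2n(-c2ccccc2)c1=O` gives 18.4%, compound 2 `O=C(Nc1ccccc1)c1c(O)c2cccnc2n(-c2ccccc2)c1=O` gives -15%, and compound 3 `COc1ccc(NC(=O)c2c(O)c3cccnc3n(-c3ccccc3)c2=O)cc1` gives -1.9%, the second highest of the three numbers. The step of a number 33.4 percentage points lower from compound 1 to compound 2 (beyond the scatter) and the step of a number 20.3 percentage points lower from compound 1 to compound 3 (beyond the scatter) both lower the number, while the step of a number 13.1 percentage points higher from compound 2 to compound 3 (beyond the scatter) raises it. Compound 4 `COc1cccc(NC(=O)c2c(O)c3cccnc3n(-c3ccccc3)c2=O)c1` differs from compound 3 by 3-methoxyphenyl in place of 4-methoxyphenyl on an amide-type nitrogen. Within the data shown here, no measured step exchanges one methoxyphenyl for the other; the only step that touches the methoxy at all, a number 13.1 percentage points higher from compound 2 to compound 3 (beyond the scatter), is modest, so little movement is expected here. Compound 4 is therefore expected to sit near 0%, within -15% to 15%. That amounts to an expected step of a number 1.9 percentage points higher from compound 3 to compound 4 (within the scatter), inside the usual scatter.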

Compound 4, a percentage reported as inhibition, in the whole organism at one dose (the size of the read-out at that dose, not a potency): 20.7%
Estimate against measurement, compound 4: 20.7 percentage points below; the measured number lies above the stated range.
By their numbers in this assay, from the lowest: compound 2; then compound 3; then compounds 1 and 4 (each within the scatter of the next).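

Moving the methoxy from 4-methoxyphenyl to 3-methoxyphenyl on the amide-type nitrogen keeps the same atoms yet gives a number 22.6 percentage points higher from compound 3 to compound 4 (beyond the scatter) in this assay, so where the methoxy sits matters, not only whether it is there. Compared with plain phenyl, the 3-methoxyphenyl group gives a number 35.7 percentage points higher from compound 2 to compound 4 (beyond the scatter). An aromatic group here can also match 2-(dimethylamino)ethyl, with a number 2.3 percentage points higher from compound 1 to compound 4 (within the scatter).

Nothing given here explains why the position matters so much. As far as these compounds go, whether 2-methoxyphenyl or 3-ethoxyphenyl at the same place would keep this number stays open.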